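The source may report more compounds than this note shows. Statements on the series, on what has been measured and on what is new or still open speak of the compounds shown alone.

In an ADME assay on Vero cells (Chlorocebus sabaeus) for cytotoxicity, read by MTT assay, with a stated time of 96 h (on this read-out higher numbers stand for lower toxicity in this test and lower numbers for higher toxicity in this test), compound 1 (`COc1ccc(-c2nc3cc(C(C)O)ccc3[nH]2)c(OC)c1`) gives > 100000 nM which is a limit of the assay. Within the data shown here, compound 2 (`COc1ccc(-c2nc3cc(/C(C)=N/NC(N)=O)ccc3[nH]2)c(OC)c1`) gives 80000 nM and holds the only actual number so far. Compound 3 (`COc1ccc(-c2nc3cc(/C(C)=N/NC(N)=O)ccc3n2C2CCCCC2)c(OC)c1`) differs from compound 2 by cyclohexyl in place of hydrogen on an aromatic nitrogen in one change: cyclohexyl in place of hydrogen on an aromatic nitrogen. Among the measured compounds shown here, the only measured step (an at least 1.2-fold lower number from compound 1 to compound 2 (0.09 log units; that floor lies within the scatter)) lies on an aromatic carbon and sets no size for that nitrogen. No step beyond the scatter is expected in this assay (a 1.5-fold lower number from compound 2 to compound 3 (0.16 log units; within the scatter)). Compound 3 is estimated at 55000 nM with a range from 15000 nM to 100000 nM as expected bounds.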

Compound 3, half-maximal cytotoxic concentration: 20000 nM
The estimate for compound 3 lay 2.8-fold (0.44 log units) above the measured number; the measured number falls inside the stated range.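

In this assay, the aromatic nitrogen of the five-membered ring responds to substitution: cyclohexyl in place of hydrogen gives a 4.0-fold lower number from compound 2 to compound 3 (0.60 log units; beyond the scatter). Among these compounds, this is the first step beyond the scatter and the first reading at this nitrogen, since the earlier step lay on an aromatic carbon. Nothing shown accounts for the size of this step.

On these data alone, whether methyl, a longer chain or a cyclohexyl bearing an amine on this nitrogen would give a step of similar size remains open. Also open, as far as these compounds go, is whether cyclohexyl there has the same effect when the aromatic carbon carries the group of compound 1.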